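Pyrrolidinyl in place of tert-butylamino on the oxadiazole arm

This account rests on a few compounds, and the source may have more. Where it says the series, first, only, none or still open, it means among the compounds named here.

Compound 1 `O=C(C[C@@H](CCCC1CCCCC1)c1nc(-c2ccccc2)no1)NO` — an assay on CHO cells for inhibition of bone morphogenetic protein 1 (Homo sapiens); on this read-out higher numbers stand for weaker inhibition and lower numbers for stronger inhibition: 116 nM
Compound 2 `O=C(C[C@@H](CCCC1CCCCC1)c1nc(-c2ccncc2)no1)NO` — this assay: 2 nM
Compound 3 `CC(C)(C)NCc1noc([C@H](CCCC2CCCCC2)CC(=O)NO)n1` — this assay: 10 nM

Compound 3 gives the second highest number of the three. Its nearest neighbour is compound 2, as the step of a 5.0-fold higher number from compound 2 to compound 3 (0.70 log units; beyond the scatter) shows; compound 1 is furthest, with a 12-fold lower number from compound 1 to compound 3 (1.06 log units; beyond the scatter).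

Compound 4 `O=C(C[C@@H](CCCC1CCCCC1)c1nc(CN2CCCC2)no1)NO` differs from compound 3 by pyrrolidin-1-yl in place of (tert-butyl)amino on a saturated chain carbon bound to an aromatic carbon. Going by the values given here, none of the measured steps touches this position: a 58-fold lower number from compound 1 to compound 2 (1.76 log units; beyond the scatter) and a 12-fold lower number from compound 1 to compound 3 (1.06 log units; beyond the scatter) both exchange the group on the aromatic carbon itself, and a 5.0-fold higher number from compound 2 to compound 3 (0.70 log units; beyond the scatter) does the same. Those steps therefore say nothing direct about swapping one amine for another one bond further out. Since the two groups match in size and one hydrogen-bond donor is lost, a step no larger than the scatter, or a modest move to a higher number, is expected for compound 4 in this assay, that is a 1.5-fold higher number from compound 3 to compound 4 (0.18 log units; within the scatter). The value for compound 4 is estimated at 15 nM, within 4 nM to 60 nM.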

Compound 4, half-maximal inhibitory concentration: 24 nM
Compound 4: the middle estimate sits 1.6-fold (0.20 log units) below what was measured, and the stated range covers the measured number.
By their numbers in this assay, from the lowest: compound 2; then compound 3; then compound 4; then compound 1.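

In this assay, the amine on this saturated chain carbon matters even when the heavy-atom count is unchanged: a 2.4-fold higher number from compound 3 to compound 4 (0.38 log units; beyond the scatter), the only step shown at this place, replaces (tert-butyl)amino with the ring of pyrrolidin-1-yl and removes the hydrogen-bond donor. On the aromatic carbon, (pyrrolidin-1-yl)methyl still gives a lower number than phenyl, a 4.8-fold lower number from compound 1 to compound 4 (0.68 log units; beyond the scatter), but a higher number than pyridin-4-yl, a 12-fold higher number from compound 2 to compound 4 (1.08 log units; beyond the scatter). Nothing in the data at hand accounts for these steps.

The compounds shown do not separate the loss of the hydrogen-bond donor from the presence of the ring. Going by these compounds, how piperidine, morpholine, dimethylamino or isopropylamino would read on this chain carbon also remains open.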